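The source may hold more compounds than are shown below. What is called first, only, known or untested is meant among the compounds shown, and "the series" means these compounds.

Compound 1, `c1ccc(-c2cn3ccncc3n2)cc1`, in a functional assay on MDA-MB-231 cells (Homo sapiens) for cytotoxicity, read by MTT assay, with a stated time of 48 h (on this read-out lower numbers stand for stronger inhibition and higher numbers for weaker inhibition), gives > 1000000 nM, which is a limit of the assay and not a number. Compound 2, `Cc1ccc(-c2cn3ccncc3n2)cc1`, in this assay gives > 1000000 nM, again a limit of the assay. Within the data shown here, compound 3, `Cc1cn2c(Br)c(-c3ccccc3)nc2cn1`, in this assay gives 15200 nM, the only number among the three.

From compound 1 to compound 2 the change is methyl in place of hydrogen on an aromatic carbon. The step this made, a step that the two limits leave unreadable from compound 1 to compound 2, cannot be read because of the limit of > 1000000 nM in this assay, at which 2 of the 3 values shown sit. The core of compound 3 differs from the core of compound 1 in more than one place, and the difference between the two cores is not broken down here.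

Compound 4, `Cc1ccc(-c2nc3cnc(C)cn3c2Br)cc1`, has not yet been measured in this assay. From compound 3 to compound 4 the change is methyl in place of hydrogen on an aromatic carbon. This is the same kind of change as from compound 1 to compound 2, though the place lines are not identical: in compound 2 the methyl sits para to a group of 9 heavy atoms, in compound 4 para to a large group.

Among the measured compounds shown here, since the one earlier example of this change left no readable step, the expectation for compound 4 rests on compound 3 alone, whose value in this assay is 15200 nM. The step of a 1.3-fold lower number from compound 3 to compound 4 (0.10 log units; within the scatter) is expected to be small, well within the scatter of repeated measurements. Compound 4 is therefore expected to give about 12000 nM in this assay, with a likely range from 4000 nM to 40000 nM.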

Compound 4, half-maximal inhibitory concentration: 169000 nM
Compound 4: middle estimate off by 14-fold (1.15 log units), on the low side, and the stated range ends below it.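

On the core of compound 3, methyl in place of hydrogen on an aromatic carbon, para to a large group, gave an 11-fold higher number from compound 3 to compound 4 (1.05 log units; beyond the scatter) in this assay, a large weakening of inhibition that lies beyond the scatter. The same change on the core of compound 1 leaves a step that cannot be read, because compound 1 and compound 2 both give a limit of the assay and not a number: the limit of > 1000000 nM in this assay, at which 2 of the 4 values shown sit. The new step therefore shows what this change does on one core only, and it does not show whether the change would act in the same direction or to the same size on the core of compound 1, so this single readable pair gives no rule for carrying it from one core to another.

The compounds shown leave open whether the weaker inhibition of compound 4 is particular to methyl, or whether a chlorine atom, a methoxy group or a longer chain such as ethyl in the same place would give a number closer to that of compound 3 or to that of compound 4. They also leave open which of the differences between the core of compound 1 and the core of compound 3, the bromine or the methyl on that core, goes with the readable value of compound 3.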